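This account rests on a few compounds, and the source may have more. Where it says the series, first, only, none or still open, it means among the compounds named here.

Compound 1 `CC(C)(C)OC(=O)N1CCC(O[C@H]2CC[C@H](Oc3ccc(S(C)(=O)=O)cc3)CC2)CC1` gives 94 nM in a functional assay on isolated protein for agonist activity at Glucose-dependent insulinotropic receptor (Rattus norvegicus), read by HTRF and cAMP accumulation; on this read-out higher numbers stand for an effect only at larger amounts of compound and lower numbers for an effect already at smaller amounts. Among the compounds with values here, compound 2 `CC(C)(C)OC(=O)N1CCC(O[C@H]2CC[C@H](Oc3ccc(S(C)(=O)=O)cc3F)CC2)CC1`, carrying a fluoro in place of hydrogen on an aromatic carbon, gives 61 nM; the only single-point step among the measured compounds, a 1.5-fold lower number from compound 1 to compound 2 (0.19 log units; within the scatter), is one the usual scatter can account for. Compound 3 `CS(=O)(=O)c1cnc(O[C@H]2CC[C@H](OC3CCN(C(=O)Oc4ccccc4)CC3)CC2)cn1`, whose shared core carries a phenoxycarbonyl group on the ring nitrogen, gives 71.8 nM; it stands second highest of the three numbers, and its gaps to compound 2 and to compound 1 both lie within the scatter, so the three measured compounds cannot be told apart in this assay.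

Compound 4 `CC(F)Cc1nc(CN2CCC(O[C@H]3CC[C@H](Oc4cnc(S(C)(=O)=O)cn4)CC3)CC2)no1` differs from compound 3 in one place: (5-(2-fluoropropyl)-1,2,4-oxadiazol-3-yl)methyl in place of phenoxycarbonyl on an amine nitrogen in a ring. Within the data shown here, the single measured step, fluoro for hydrogen on an aromatic carbon, concerns a different part of the molecule and is itself within the scatter, so nothing measured here speaks directly to exchanging phenoxycarbonyl for (5-(2-fluoropropyl)-1,2,4-oxadiazol-3-yl)methyl on an amine nitrogen in a ring. Among the measured compounds shown here, the only reference point is compound 3 with 71.8 nM. Compound 4 is therefore expected to show a 1.1-fold higher number from compound 3 to compound 4 (0.05 log units; within the scatter), no change separable from the scatter, though with wide uncertainty. The estimate for compound 4 is 80 nM, ranging from 15 nM to 450 nM.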

Compound 4, half-maximal effective concentration: 267 nM
Compound 4: middle estimate off by 3.3-fold (0.52 log units), on the low side; measured number inside the range.
By their numbers in this assay, from the lowest: compounds 2, 3 and 1 (each within the scatter of the next); then compound 4.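

Within the data shown here, at the amine nitrogen in a ring of the shared core, the exchange of phenoxycarbonyl for (5-(2-fluoropropyl)-1,2,4-oxadiazol-3-yl)methyl gives in this assay a 3.7-fold higher number from compound 3 to compound 4 (0.57 log units; beyond the scatter) and thereby shows that this position does not tolerate every group equally, something the one earlier step, made on an aromatic carbon elsewhere and within the scatter, could not show. The exchange alters several things at once: a six-membered aromatic ring of carbon only and a double bond outside aromatic rings leave, a five-membered aromatic ring with 3 hetero atoms and a fluorine enter, and neither group carries a net charge, so this single step does not separate these features from one another. No measurement offered here explains the higher number of compound 4.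

On these data alone, it remains open whether the change in the number follows the five-membered ring itself or the 2-fluoropropyl chain it carries, a question that a plain propyl chain or a cyclopropyl group in that place would address. Also open, as far as these compounds go, is how a simple acetyl group or a benzyl group on the same amine nitrogen would read out.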